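This account rests on a few compounds, and the source may have more. Where it says the series, first, only, none or still open, it means among the compounds named here.

Of the compounds shown here, three have been measured in a functional assay on DU-145 cells (Homo sapiens) for inhibition, read by trypan blue exclusion, with a stated time of 96 h; on this read-out lower numbers stand for stronger inhibition of growth and higher numbers for weaker inhibition of growth. Compound 1 `O=C(/C(=C\c1c[nH]c2ccc(Cl)cc12)SCc1ccc(F)cc1)c1ccc(Br)cc1` gives 1000 nM in this assay. Compound 2 `Cc1ccc(S(=O)(=O)/C(=C/c2ccc(C)s2)C(=O)c2ccc(Cl)cc2)cc1` gives 50000 nM, and compound 3 `Cc1ccc(/C=C(\C(=O)c2ccc(Cl)cc2)S(=O)(=O)Cc2ccc(F)cc2)s1` gives 50000 nM. Compound 1 stands lowest of the three, and both compound 2 and compound 3 lie at a markedly higher number, beyond the scatter. How the core of compound 1 differs from that of compound 3 is not broken down here.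

Compound 2 and compound 3 share a core and differ in one place: 4-methylphenyl in place of 4-fluorobenzyl on a sulfonyl sulfur The step of no change at the digits printed from compound 3 to compound 2 (within the scatter) lies within the scatter.

Compound 4 `Cc1ccc(S/C(=C/c2c[nH]c3ccc(Cl)cc23)C(=O)c2ccc(Br)cc2)cc1` has not yet been measured in this assay. Among the compounds with values here, it differs from compound 1 in one place: 4-methylphenyl in place of 4-fluorobenzyl on a sulfur This is the same kind of change as the one from compound 3 to compound 2, but not the same: in compound 3 the group sits on a sulfonyl sulfur whose other neighbours are a double-bonded chain carbon, whereas in compound 1 it sits on a sulfur whose other neighbours are a double-bonded chain carbon, and the two cores also differ.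

Because the step of no change at the digits printed from compound 3 to compound 2 (within the scatter) was flat, the step of no change at the digits printed from compound 1 to compound 4 (within the scatter) is expected to be small as well, with added uncertainty from the different place and core. Compound 4 is expected to give about 1000 nM in this assay, most likely between 300 nM and 5000 nM.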

Compound 4, concentration for 50% growth inhibition: 1000 nM
Estimate against measurement, compound 4: no gap at the digits printed; the measured number falls inside the stated range.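

In this assay, putting 4-methylphenyl in place of 4-fluorobenzyl on the sulfur gave no change at the digits printed from compound 1 to compound 4 (within the scatter). Set beside the same change on a sulfonyl sulfur in a different core, the result reads alike on both cores: the same change on two cores in this assay, no change at the digits printed (within the scatter) from compound 3 to compound 2 and no change at the digits printed (within the scatter) from compound 1 to compound 4, 1.0-fold (0.00 log units) apart, within the scatter of two such steps This shows that, in the two cases at hand, the swap between these two groups carries from one core to the other without a visible shift in growth inhibition, but it rests on one pair of groups and only two cores, and it does not show that the change would stay flat on any further core in the series, nor which part of the swap, the loss of the fluorine or the difference between benzyl and phenyl, would matter if taken alone.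

The compounds shown leave open how the core of compound 1 responds to groups of another kind on this sulfur, such as a longer alkyl chain, or a phenyl ring carrying an amine or a carboxylic acid. They also leave open what a sulfonyl sulfur in place of the sulfur would do on the core of compound 1.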